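The compounds below may be only part of what the source reports. "The series", "measured", "known", "first", "only" and "open" are said of these compounds alone.

Working notes on the series. Compound 1 `COc1ccc(Sc2ccccc2N2CC(C)N(CC(=O)O)CC2C)cc1` is measured in an assay for inhibition of sodium- and chloride-dependent glycine transporter 1 (Homo sapiens) (on this read-out higher numbers stand for weaker inhibition and lower numbers for stronger inhibition), at 580 nM and stands lowest of the two numbers recorded so far. Compound 2 `COc1ccc(Sc2ccccc2N2C[C@H](C)N(CC(=O)O)C[C@H]2C)cc1` gives 53000 nM in this assay. The step of a 91-fold higher number from compound 1 to compound 2 (1.96 log units; beyond the scatter) is large; the two compounds share all atoms and bonds and differ only in whether the two ring stereocentres are drawn with a configuration, which is what the fact that one of compounds 1 and 2 is drawn with a defined configuration and the other without, at the place where they differ records.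

Compound 3 `Cc1ccc(Sc2ccccc2N2CC(C)N(CC(=O)O)CC2C)cc1` is not yet measured. It differs from compound 1 by methyl in place of methoxy on an aromatic carbon. Among the compounds with values here, no measured step touches the substituent on this aromatic ring; the single recorded step is the stereochemical one, and it carries no information about a methyl in place of a methoxy. With no comparison at hand, the step in this assay is expected to stay within the scatter, in either direction, and the estimate means a 1.4-fold higher number from compound 1 to compound 3 (0.14 log units; within the scatter). Compound 3 is accordingly estimated at 800 nM, with a range from 250 nM to 3000 nM.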

Compound 3, half-maximal inhibitory concentration: 550 nM
Beside the measured number, compound 3's estimate is 1.5-fold (0.16 log units) above it; the range from low to high includes it.
By their numbers in this assay, from the lowest: compounds 3 and 1 (each within the scatter of the next); then compound 2.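

In this assay, methyl in place of methoxy on this aromatic carbon, para to a large group, gives a 1.1-fold lower number from compound 1 to compound 3 (0.02 log units; within the scatter) and so does not move the reading beyond the scatter. The change takes away the oxygen and the one hydrogen-bond acceptor counted in the methoxy, so neither is required at this position for a number of this size. No recorded evidence bears on why the two groups read alike.

Going by these compounds, whether the position accepts other groups, such as an amine, a chlorine atom or a longer alkyl chain, remains open. Also open, on these data alone, is whether the same substitution reads alike on the defined configuration of compound 2, which stands far higher in this assay at 53000 nM and carries the methoxy.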